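Swapping One Halogen for Another on a Shared Core

The source may hold more compounds than are shown below. What is called first, only, known or untested is meant among the compounds shown, and "the series" means these compounds.

Of the compounds shown here, three built on the same core have been tested in a functional assay on C6 cells (Rattus norvegicus) for cytotoxicity, read by MTT assay, with a stated time of 24 h, tested at 12 ug/mL; a higher number here means a weaker effect of the compound at the concentration tested, a lower number a stronger effect. Compound 1 `Cc1ccc(-c2cs/c(=N/NC(=O)CSc3nnnn3-c3ccccc3)n2-c2ccccc2)cc1` gives 55.1%. Compound 2 `Cn1nnnc1SCC(=O)N/N=c1/scc(-c2ccccc2)n1-c1ccccc1` gives 80.7%. Compound 3 `O=C(CSc1ncccn1)N/N=c1/scc(-c2ccc(Br)cc2)n1-c1ccccc1` gives 72.1%, the second highest of the three numbers; the nearest neighbour is compound 2, which sits within the usual scatter of compound 3, and the furthest is compound 1, whose lower number lies beyond that scatter.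

Compound 4 `O=C(CSc1ncccn1)N/N=c1/scc(-c2ccc(F)cc2)n1-c1ccccc1` has not been measured. It differs from compound 3 in a single place: fluoro in place of bromo on an aromatic carbon. Among the compounds with values here, no pair of measured compounds differs only in this way, so nothing measured here shows what such a change does in this assay; the three measured compounds differ from one another in more than one place. With no such guide, the plain expectation is a step no larger than the scatter, in no particular direction. Compound 4 is therefore expected to give about 74%, with a range from 58% to 90%. This estimate means a step of a number 1.9 percentage points higher from compound 3 to compound 4 (within the scatter) that is expected to stay within the scatter.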

Compound 4, a percentage reported as activity, at one concentration (the size of the read-out at that concentration, not a potency): 77.4%
The estimate for compound 4 lay 3.4 percentage points below the measured number, and the stated range covers the measured number.
By their numbers in this assay, from the lowest: compound 1; then compounds 3, 4 and 2 (each within the scatter of the next).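

In this assay, within the data shown here, the change from 4-bromophenyl to 4-fluorophenyl gives a number 5.3 percentage points higher from compound 3 to compound 4 (within the scatter) and is the first single-place comparison available on this core. At this position on the aromatic ring, then, the two halogens cannot be told apart in this assay, and this single pair gives no sign that the choice between bromo and fluoro matters here. No evidence is available on why the swap has so little visible effect.

Still open, going by these compounds, is whether a group of another kind at this position, such as an amine, a carboxylic acid or a methoxy group, would move the number beyond the scatter. It is also unknown whether chloro would behave like bromo and fluoro, or whether the same swap would give a similarly small step with different groups elsewhere on the core.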